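Aromatase inhibition: removing the propyl chain from compound 3

The compounds below may be only part of what the source reports. "The series", "measured", "known", "first", "only" and "open" are said of these compounds alone.

Among the three compounds with measured numbers, compound 3 `CCCOc1ccc(C(=O)c2cccc(Cn3ccnc3)c2)cc1` stands lowest in an assay on isolated protein for inhibition of Aromatase (Homo sapiens), read by fluorescence, with stated times of 10 min and 60 min (on this read-out higher numbers stand for weaker inhibition and lower numbers for stronger inhibition), where compound 3 gives 2 nM. Compound 1 `CCCCCOc1ccc(C(=O)c2cccc(Cn3ccnc3)c2)cc1` gives 42 nM in this assay, and compound 2 `C#CCOc1ccc(C(=O)c2cccc(Cn3ccnc3)c2)cc1` gives 650 nM. The steps between them are all large: a 21-fold lower number from compound 1 to compound 3 (1.32 log units; beyond the scatter), a 15-fold higher number from compound 1 to compound 2 (1.19 log units; beyond the scatter) and a 330-fold lower number from compound 2 to compound 3 (2.51 log units; beyond the scatter).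

Compound 4 `O=C(c1ccc(O)cc1)c1cccc(Cn2ccnc2)c1` differs from compound 3 by hydrogen in place of propyl on an oxygen on an aromatic ring. Within the data shown here, none of the measured steps removes the chain altogether; the steps from compound 1 to compound 3 and from compound 2 to compound 3 only change what sits on the saturated chain carbon bound to the ring oxygen, and both show that this assay answers such changes with large shifts. The step to compound 4 takes away the whole chain, which lies outside what the measured steps cover, so the direction can only be guessed from the fact that compound 3 already holds the lowest number. On that basis compound 4 is expected to give a weaker result, with the step of a 75-fold higher number from compound 3 to compound 4 (1.88 log units; beyond the scatter) estimated as large but uncertain. The estimate for compound 4 in this assay is 150 nM, within a range from 10 nM to 2000 nM.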

Compound 4, half-maximal inhibitory concentration: 13 nM
Estimate against measurement, compound 4: 12-fold (1.06 log units) above, within the range that was stated.
By their numbers in this assay, from the lowest: compound 3; then compound 4; then compound 1; then compound 2.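

In this assay, removing the whole propyl chain from the ring oxygen gives only a modest change, a 6.5-fold higher number from compound 3 to compound 4 (0.81 log units; beyond the scatter), which is smaller than the large steps seen among the chains themselves. The same position therefore tolerates bare hydroxy, and the chain is not required for a low number: there is a 3.2-fold lower number from compound 1 to compound 4 (0.51 log units; beyond the scatter) and a 50-fold lower number from compound 2 to compound 4 (1.70 log units; beyond the scatter), so of the groups compared, only propyl gives a lower number than hydrogen, while pentyl and propargyl both give higher ones. Nothing available accounts for this order of propyl, hydrogen, pentyl and propargyl on the oxygen.

The compounds shown leave open how the number moves at other chain lengths, such as a methyl, ethyl or butyl group on this oxygen, and so whether the low number of propyl belongs to a narrow range of chains or a broader one. They also leave open what a branched chain such as isopropyl would give, and what would follow from an amine in place of the oxygen or a carboxylic acid at the end of the chain.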